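The compounds below may be only part of what the source reports. "The series", "measured", "known", "first", "only" and "open" are said of these compounds alone.

Working notes on the lactone series in an assay for inhibition of 3-hydroxy-3-methylglutaryl-coenzyme A reductase (Rattus norvegicus); a higher number here means a weaker inhibitor, a lower number a stronger inhibitor.

Of the compounds shown here, three carry numbers so far. Compound 1 `O=C1C[C@H](O)C[C@@H](/C=C/c2ccccc2-c2ccccc2)O1` gives 3000 nM in this assay. Compound 2 `O=C1C[C@H](O)CC(CCc2c(Cl)cc(Cl)cc2-c2ccccc2)O1` gives 100 nM. Compound 3 `Cc1cc(F)ccc1-c1cc(Cl)cc(Cl)c1/C=C/[C@@H]1C[C@@H](O)CC(=O)O1`, which bears the two chloro groups and the 4-fluoro-2-methylphenyl group on the shared core, gives 36 nM and stands at the low end of the three numbers; its nearest neighbour is compound 2, and the gap between the two lies beyond the usual scatter, while the gap to compound 1 is far larger.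

Compound 4 `CCc1cccc(-c2cc(Cl)cc(Cl)c2/C=C/[C@@H]2C[C@@H](O)CC(=O)O2)c1` has not been measured. It differs from compound 3 in one place: 3-ethylphenyl in place of 4-fluoro-2-methylphenyl on an aromatic carbon. Among the measured compounds shown here, no pair of measured compounds differing only in this group exists, so the size of the step rests on judgement alone. Given that compound 3 gives 36 nM with the related aryl group in the same place, the step from compound 3 to compound 4 is expected to be small, a 1.7-fold higher number from compound 3 to compound 4 (0.22 log units; within the scatter), tending toward a slightly higher number, if beyond the scatter at all. Compound 4 is therefore estimated at 60 nM, with a range from 20 nM to 200 nM.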

Compound 4, half-maximal inhibitory concentration: 44 nM
The estimate for compound 4 lay 1.4-fold (0.13 log units) above the measured number, and the stated range covers the measured number.
By their numbers in this assay, from the lowest: compounds 3 and 4 (each within the scatter of the next); then compound 2; then compound 1.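

Replacing 4-fluoro-2-methylphenyl with 3-ethylphenyl on this aromatic carbon, ortho to a large group and meta to two chloro groups, gives a 1.2-fold higher number from compound 3 to compound 4 (0.09 log units; within the scatter) in this assay. Among the compounds shown here, this is the first one-place comparison at this position, and it shows that two differently substituted phenyl groups, one with fluorine and one with only carbon, cannot be told apart by this read-out. No measurement on hand bears on why the two groups read alike.

On these data alone, whether this holds for a phenyl group carrying an amine or a carboxylic acid, or for a propyl or longer chain in place of the ethyl, remains open. For the compounds shown here, the role of the two chloro groups also remains open, as no pair of compounds here varies them alone.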